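Swapping a Furan for a Phenyl on a Tetrazole Ketone

The source may report more compounds than this note shows. Statements on the series, on what has been measured and on what is new or still open speak of the compounds shown alone.

Measured so far:
compound 1, `N#Cc1cccc(-c2ccc(C(=O)CCCCCCc3ccccc3)nn2)n1`, 390 nM in an assay for inhibition of Fatty-acid amide hydrolase 1 (Rattus norvegicus), at pH 9.0; a higher number here means a weaker inhibitor, a lower number a stronger inhibitor
compound 2, `O=C(CCCCCCc1ccccc1)c1nnn(-c2ccco2)n1`, 5 nM in this assay

Of the two compounds measured, compound 2 has the lower number, and therefore the stronger inhibition. Within the data shown here, compound 1, its only neighbour, carries a different ring system and gives a value that lies far above it, well beyond the scatter of repeated measurements.

Compound 3, `O=C(CCCCCCc1ccccc1)c1nnn(-c2ccccc2)n1`, keeps the whole ketone chain and the five-membered ring of compound 2 and changes only the ring attached to the ring nitrogen: phenyl in place of furan-2-yl on an aromatic nitrogen. Among the measured compounds shown here, no pair of measured compounds differs in just this way, so the size of this step cannot be read from the data at hand. The change is small compared with the difference between compound 1 and compound 2, so a modest step is expected, most likely toward a somewhat higher number, though a result within the scatter of compound 2 would not surprise. Compound 3 is therefore estimated at 15 nM in this assay, with a likely range from 4 nM to 60 nM, which corresponds to an expected step of a 3.0-fold higher number from compound 2 to compound 3 (0.48 log units; beyond the scatter).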

Compound 3, inhibition constant: 16 nM
The estimate for compound 3 lay 1.1-fold (0.03 log units) below the measured number, within the range that was stated.
By their numbers in this assay, from the lowest: compound 2; then compound 3; then compound 1.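

In this assay, putting phenyl in place of furan-2-yl on the aromatic nitrogen gives a 3.2-fold higher number from compound 2 to compound 3 (0.51 log units; beyond the scatter), so the number responds to the ring at this position, although the step is modest. Among these compounds, this is the first pair that differs in only one place, which makes it the first direct reading of what this position contributes. The ring that enters is larger by one heavy atom and has carbon only, with no hydrogen-bond acceptor, yet compound 3 still reaches 16 nM, so the furan oxygen is not needed for a value in the low range seen here, though nothing available explains why the two rings differ.

On these data alone, it remains open whether a thiophene or a pyridine at this position would match furan-2-yl, and whether a nitrile, a methoxy group or a carboxylic acid on the phenyl ring would move the number in either direction. As far as these compounds go, the effect of a shorter or longer chain between the ketone and the far phenyl ring also remains open, as does whether the step seen here would keep its size with such a chain.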